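The source may hold more compounds than are shown below. What is called first, only, known or untested is meant among the compounds shown, and "the series" means these compounds.

Compound 1 `CCCCC/C=C/CCCCCCCCCC1(C(=O)OC)CO1` was tested in a functional assay on the whole organism with Rattus norvegicus as the target, in the glucose tolerance test (on this read-out higher numbers stand for an effect only at larger amounts of compound and lower numbers for an effect already at smaller amounts), and gave 10 mg/kg. In this assay compound 2 `CCCCCCCCCCCCCCC1(C(=O)OCC(O)CO)CO1` gave 5 mg/kg, and compound 3 `CCCCCCCCCCCCCCC1(C(=O)N(C)C)CO1` gave 25 mg/kg, so compound 1 stands second highest of the three, close to compound 2 and further from compound 3. Among the measured compounds shown here, the only step measured, a 5.0-fold higher number from compound 2 to compound 3 (0.70 log units; beyond the scatter), concerns the group on the carbonyl carbon. Compound 4 `CCCCCCCCCCC1(C(=O)OC)CO1` differs from compound 1 at the far end of the chain: methyl in place of hept-1-en-1-yl on a saturated chain carbon, nine bonds along the chain from a saturated ring carbon. For the measured compounds named here, no measured step shortens the chain, so the step from compound 2 to compound 3 offers no guide here. The account therefore expects for compound 4 a number near that of compound 1, estimated at 15 mg/kg within a range of 5 mg/kg to 50 mg/kg. This is expected to be a step of a 1.5-fold higher number from compound 1 to compound 4 (0.18 log units; within the scatter), not beyond the scatter.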

Compound 4, minimum effective dose: 10 mg/kg
Compound 4: the middle estimate sits 1.5-fold (0.18 log units) above what was measured; the range from low to high includes it.
By their numbers in this assay, from the lowest: compounds 2, 1 and 4 (each within the scatter of the next); then compound 3.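

In this assay, among the compounds shown here, methyl in place of hept-1-en-1-yl on a saturated chain carbon, nine bonds along the chain from a saturated ring carbon, gives no change at the digits printed from compound 1 to compound 4 (within the scatter), the first measured change at the far end of the chain. The shorter saturated chain of compound 4 therefore keeps the effect seen with compound 1 on this read-out. No measurement given here explains this result.

On these data alone, whether a phenyl group or a carboxylic acid at the chain end would do the same remains open. So does whether the group on the carbonyl carbon acts the same way on the shorter chain.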